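Fluoro for chloro on a chalcone triazole: cytotoxicity outlook

A few compounds are considered here, and "the series" means these few. Any claim that something is new, unique, unknown or untested is made for them only; others in the source may bear on it.

Measured compounds in an ADME assay on Huh-7 cells (Homo sapiens) for cytotoxicity, read by MTT assay, with a stated time of 72 h; on this read-out higher numbers stand for lower toxicity in this test and lower numbers for higher toxicity in this test:
compound 1 `COc1cc(O)c(C(=O)/C=C/c2ccc(OCc3cn(-c4ccc(F)cc4Cl)nn3)c(OC)c2)c(OC)c1`, which gives > 100 ug/mL;
compound 2 `COc1cc(OC)c2c(=O)cc(-c3ccc(OCc4cn(-c5ccc(Cl)cc5)nn4)c(OC)c3)oc2c1`, which gives > 100 ug/mL;
compound 3 `COc1cc(OC)c2c(=O)cc(-c3ccc(OCc4cn(-c5ccc(F)c(Cl)c5)nn4)c(OCc4cn(-c5ccc(F)c(Cl)c5)nn4)c3)oc2c1`, which gives > 100 ug/mL.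

Compound 1 is known in this assay only as a limit of the assay, not as a number. Compound 2 likewise sits at a limit in this assay. Compound 3 also sits at a limit in this assay. So the three values form no ranking at all: every one of them stands at the limit of > 100 ug/mL in this assay, at which 3 of the 3 values shown sit, and nothing separates them. Compound 1 therefore stands level with the other two, at the limit and no lower.

Compound 4 `COc1cc(O)c(C(=O)/C=C/c2ccc(OCc3cn(-c4ccc(F)cc4F)nn3)c(OC)c2)c(OC)c1` differs from compound 1 in one place: fluoro in place of chloro on an aromatic carbon, or in words, fluoro in place of chloro on an aromatic carbon. Among the compounds with values here, no step between two measured compounds is available, so the size of this change in this assay must be expected rather than read. Since all three measured compounds sit at the limit, the expectation is for no step beyond the scatter, and for compound 4 to remain at the limit as well; the step that the limit leaves unreadable from compound 1 to compound 4 is what that estimate means. Compound 4 is thus estimated at 150 ug/mL, with the range 70 ug/mL to 300 ug/mL.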

Compound 4, half-maximal cytotoxic concentration: > 100 ug/mL
Compound 4 gave a limit, no number; the forecaster's own chance of this, stated with the estimate: 85%; the middle value lies beyond the limit too.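

Within the data shown here, compound 1 and compound 4 both stand at a limit, so fluoro in place of chloro gives no step that can be read: the limit of > 100 ug/mL in this assay, at which 4 of the 4 values shown sit. The compounds shown leave open how far past that limit each one lies, and whether this change alters cytotoxicity at all.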